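Aryl Swaps on a Triazole-Linked Bicyclic Lactam Core

A few compounds are considered here, and "the series" means these few. Any claim that something is new, unique, unknown or untested is made for them only; others in the source may bear on it.

Compound 1 `CC1(C)[C@H]2CC[C@]1(C)N(Cc1cn(-c3ccccc3Cl)nn1)C(=O)C2`: 220 nM
Compound 2 `CC1(C)[C@H]2CC[C@]1(C)N(Cc1cn(-c3ccccc3)nn1)C(=O)C2`: 240 nM
Compound 3 `CC1(C)[C@H]2CC[C@]1(C)N(Cc1cn(-c3cccc(Br)c3)nn1)C(=O)C2`: 120 nM

In a functional assay on SGC-7901 cells (Homo sapiens) for inhibition, read by MTT assay, with a stated time of 24 h (a lower number here means a stronger inhibitor, a higher number a weaker inhibitor), compound 1 gives 220 nM, the second highest of the three numbers; its neighbours are compound 2, at a 1.1-fold higher number from compound 1 to compound 2 (0.04 log units; within the scatter), and compound 3, at a 1.8-fold lower number from compound 1 to compound 3 (0.26 log units; within the scatter). Compound 4 `Cc1cccc(-n2cc(CN3C(=O)C[C@@H]4CC[C@@]3(C)C4(C)C)nn2)c1` is not yet measured. It differs from compound 1 by 3-methylphenyl in place of 2-chlorophenyl on an aromatic nitrogen. Among the compounds with values here, the steps that bear on it, a 1.1-fold higher number from compound 1 to compound 2 (0.04 log units; within the scatter) and a 2.0-fold lower number from compound 2 to compound 3 (0.30 log units; within the scatter) as well as a 1.8-fold lower number from compound 1 to compound 3 (0.26 log units; within the scatter), all lie within the scatter, so the aryl substituent pattern has so far left the readout where it was. No step beyond the scatter is therefore expected in this assay for compound 4. Compound 4 is expected to give about 180 nM, within 90 nM to 360 nM, which corresponds to the estimated step of a 1.2-fold lower number from compound 1 to compound 4 (0.09 log units; within the scatter).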

Compound 4, half-maximal inhibitory concentration: 410 nM
For compound 4 the middle estimate is 2.3-fold (0.36 log units) below the measured one, outside the stated range (above it).
By their numbers in this assay, from the lowest: compounds 3, 1, 2 and 4 (each within the scatter of the next, the first and the last beyond it).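

In this assay the aryl group now gives a step beyond the scatter, a 3.4-fold higher number from compound 3 to compound 4 (0.53 log units; beyond the scatter), with methyl in place of bromo on an aromatic carbon. The two other steps, a 1.7-fold higher number from compound 2 to compound 4 (0.23 log units; within the scatter) and a 1.9-fold higher number from compound 1 to compound 4 (0.27 log units; within the scatter), stay within the scatter, so methyl cannot be separated from hydrogen on that carbon, nor 3-methylphenyl from 2-chlorophenyl. No measurement shown accounts for the gap between bromo and methyl.

On these data alone, whether a methoxy group, an amine or a carboxylic acid on that carbon would read with bromo or with methyl remains open.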